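A few compounds are considered here, and "the series" means these few. Any claim that something is new, unique, unknown or untested is made for them only; others in the source may bear on it.

Compound 1 `COc1ccc2oc(-c3cn4nc(OC)sc4n3)cc2c1`: in an assay for antagonist activity at proteinase-activated receptor 4 (Homo sapiens), with stated times of 5 min, 50 s and 15 min, in the presence of a further agent that is not named here (a higher number here means a weaker inhibitor, a lower number a stronger inhibitor), compound 1 reaches only the limit > 30000 nM.
Compound 2 `CS(=O)(=O)c1nn2cc(-c3cc4ccccc4o3)nc2s1`: compound 2 likewise sits at the limit > 30000 nM.
Compound 3 `COc1nn2cc(-c3cc4c(OC)ccc(OC)c4o3)nc2s1`: compound 3 gives 2100 nM.

Compound 2 therefore stands on a bound rather than a number; the same is true of compound 1, and only compound 3 returns a measured half-maximal inhibitory concentration. The set is shaped by the limit of > 30000 nM in this assay, at which 2 of the 3 values shown sit, so the standing of compound 2 can only be said to be at or beyond that bound, without any ordering against compound 1.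

Compound 4 `c1ccc2oc(-c3cn4nc(C5CC5)sc4n3)cc2c1` has not yet been tested. It follows from compound 2 by cyclopropyl in place of methylsulfonyl on an aromatic carbon. Going by the values given here, no measured pair in this set differs in one place, so there is no measured step to lean on; the only measured number, that of compound 3, belongs to a differently substituted partner. The step from compound 2 to compound 4 is expected to be small to moderate toward stronger inhibition, an at least 1.5-fold lower number from compound 2 to compound 4 (0.17 log units; that floor lies within the scatter), with a fair chance that it stays within the bound. Compound 4 is estimated at 20000 nM, in a range from 3000 nM to 100000 nM.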

Compound 4, half-maximal inhibitory concentration: > 30000 nM
Compound 4: a limit, no number (the forecaster's own chance of this, stated with the estimate: 55%); middle value at least 1.5-fold (0.17 log units) away from the limit.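

Compound 4 returns > 30000 nM as a limit and not a number. Compound 2 also stands on a limit, so replacing methylsulfonyl with cyclopropyl gives no readable step between compound 2 and compound 4: the limit of > 30000 nM in this assay, at which 3 of the 4 values shown sit.

Whether cyclopropyl and methylsulfonyl differ at all in this assay remains open in the compounds shown.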